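Swapping acetyl for benzoyl on a cytotoxic scaffold

The source may hold more compounds than are shown below. What is called first, only, known or untested is meant among the compounds shown, and "the series" means these compounds.

Compound 1 `CC(=O)N1c2ccccc2CCC1C(=O)Nc1ccccc1O` is the weaker of the two compounds measured here: in a functional assay on HCT-15 cells (Homo sapiens) for cytotoxicity, read by sulforhodamine B assay, with a stated time of 72 h (a lower number here means a stronger inhibitor of growth, a higher number a weaker inhibitor of growth), compound 1 gives 54500 nM, while compound 2 `O=C(Nc1ccc(C(F)(F)F)cc1)C1CCc2ccccc2N1` gives 17600 nM, a gap beyond the usual scatter. Compound 3 `O=C(Nc1ccccc1O)C1CCc2ccccc2N1C(=O)c1ccccc1` differs from compound 1 by phenyl in place of methyl on a carbonyl carbon; in other words, acetyl becomes benzoyl. Going by the values given here, no measured pair shows this change, so its effect is unknown. A modest gain, not clearly beyond the scatter, is expected for a 1.4-fold lower number from compound 1 to compound 3 (0.13 log units; within the scatter). Compound 3 is therefore estimated at 40000 nM, with a range from 10000 nM to 120000 nM.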

Compound 3, concentration for 50% growth inhibition: 3830 nM
Compound 3: the middle estimate sits 10-fold (1.02 log units) above what was measured; measured number below the stated range.
By their numbers in this assay, from the lowest: compound 3; then compound 2; then compound 1.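

Turning acetyl into benzoyl on the ring amide-type nitrogen gives a 14-fold lower number from compound 1 to compound 3 (1.15 log units; beyond the scatter). So this position accepts a much larger group, and the change strengthens growth inhibition rather than losing it, which the earlier compounds could not show because they differ in more than one place. Nothing available explains why the number falls. The compounds shown leave open whether the aromatic ring itself matters. A cyclohexyl group or a longer chain such as butyl on the same carbonyl carbon could separate that from sheer size.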